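The source may report more compounds than this note shows. Statements on the series, on what has been measured and on what is new or still open speak of the compounds shown alone.

Of the compounds shown here, three that share one core have been measured in an assay on microsomes from liver for inhibition of acyl-CoA desaturase 1 (Rattus norvegicus); on this read-out higher numbers stand for weaker inhibition and lower numbers for stronger inhibition. Compound 1 `Cc1nnc(-c2ccc(N3CCC(Oc4ccccc4C(F)(F)F)CC3)nn2)s1` gives 2.3 nM in this assay. Compound 2 `CC(C)c1nnc(-c2ccc(N3CCC(Oc4ccccc4C(F)(F)F)CC3)nn2)s1` gives 8.8 nM, and compound 3 `OCc1nnc(-c2ccc(N3CCC(Oc4ccccc4C(F)(F)F)CC3)nn2)s1` gives 3.2 nM. On these numbers compound 3 stands second highest of the three: its number and that of compound 1 lie within the scatter of each other, while compound 2 is set apart by a 2.8-fold lower number from compound 2 to compound 3 (0.44 log units; beyond the scatter).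

The unmeasured compound 4 `FC(F)(F)c1ccccc1OC1CCN(c2ccc(-c3nnco3)nn2)CC1` differs from compound 3 in one place: 1,3,4-oxadiazol-2-yl in place of 5-(hydroxymethyl)-1,3,4-thiadiazol-2-yl on an aromatic carbon. Going by the values given here, two measured steps touch this part of the structure. The step of a 3.8-fold higher number from compound 1 to compound 2 (0.58 log units; beyond the scatter) shows that a larger group on that ring carbon goes with a weaker result, whereas the step of a 1.4-fold higher number from compound 1 to compound 3 (0.14 log units; within the scatter) shows that exchanging methyl for hydroxymethyl changes nothing beyond the scatter. Neither step exchanges the five-membered ring itself, and none removes its substituent altogether, so the change to compound 4 reaches further than anything measured here.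

Given that the small groups at this position behave alike, compound 4 is expected to stay close to compound 3, with a modest weakening allowed for, giving an expected step of a 2.2-fold higher number from compound 3 to compound 4 (0.34 log units; beyond the scatter). The estimate for compound 4 in this assay is 7 nM, with a range from 2 nM to 30 nM.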

Compound 4, half-maximal inhibitory concentration: 22 nM
For compound 4 the middle estimate is 3.1-fold (0.50 log units) below the measured one, within the range that was stated.
By their numbers in this assay, from the lowest: compounds 1 and 3 (each within the scatter of the next); then compound 2; then compound 4.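

In this assay, going by these compounds alone, compound 4 brings the first change at this position that exchanges the five-membered ring itself and removes its substituent, and replacing the 5-(hydroxymethyl)-1,3,4-thiadiazol-2-yl group gives a 6.9-fold higher number from compound 3 to compound 4 (0.84 log units; beyond the scatter) while replacing the 5-methyl-1,3,4-thiadiazol-2-yl group gives a 9.6-fold higher number from compound 1 to compound 4 (0.98 log units; beyond the scatter) on the same read-out. Even the 5-isopropyl-1,3,4-thiadiazol-2-yl group, which had the highest number of the earlier three, stands lower, with a 2.5-fold higher number from compound 2 to compound 4 (0.40 log units; beyond the scatter) for the exchange, so the earlier link between a larger group and a weaker result does not hold here: compound 4 carries the smaller group, yet has the highest number of the four. Nothing measured here explains this weakening.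

Ring and substituent change together in this exchange, so the compounds shown cannot say how much of the step belongs to oxygen replacing sulfur in the ring and how much to the lost substituent. From the compounds shown here alone, a 1,3,4-oxadiazol-2-yl ring carrying methyl, or a 1,3,4-thiadiazol-2-yl ring with no substituent, would separate the two, and how an amine on that ring carbon would behave also remains open.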